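A few compounds are considered here, and "the series" means these few. Any claim that something is new, unique, unknown or untested is made for them only; others in the source may bear on it.

Of the compounds shown here, three sharing one core have been tested in a functional assay on HepG2 cells (Homo sapiens) for antiproliferative activity, read by MTT assay; a lower number here means a stronger inhibitor, a higher number a weaker inhibitor. Compound 1 `Cc1c(-n2cc(COc3ccc(/C=C/C(=O)c4cc5c(cc4O)OC(C)(C)CC5)cc3)nn2)cccc1[N+](=O)[O-]` gives 109000 nM, compound 3 `CCc1ccccc1-n1cc(COc2ccc(/C=C/C(=O)c3cc4c(cc3O)OC(C)(C)CC4)cc2)nn1` gives 115000 nM, and compound 2 `COc1ccc(-n2cc(COc3ccc(/C=C/C(=O)c4cc5c(cc4O)OC(C)(C)CC5)cc3)nn2)c([N+](=O)[O-])c1` is reported as "not active" (no number reported). For the measured compounds named here, compound 3 therefore holds one of only two numbers, and these lie within the scatter of each other. Going by the values given here, the one measured step is a 1.1-fold higher number from compound 1 to compound 3 (0.02 log units; within the scatter), with 2-ethylphenyl in place of 2-methyl-3-nitrophenyl on an aromatic nitrogen. Compound 4 `CCCCCCCCn1cc(COc2ccc(/C=C/C(=O)c3cc4c(cc3O)OC(C)(C)CC4)cc2)nn1` changes that same place: octyl in place of 2-ethylphenyl on an aromatic nitrogen, octyl in place of 2-ethylphenyl. Among the compounds with values here, no measured compound carries a chain there, so the expectation is loose. The expected step is a 1.2-fold lower number from compound 3 to compound 4 (0.06 log units; within the scatter), none beyond the scatter. For compound 4 the estimate is 100000 nM, with an expected range of 35000 nM to 200000 nM.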

Compound 4, half-maximal inhibitory concentration: 127000 nM
Beside the measured number, compound 4's estimate is 1.3-fold (0.10 log units) below it; the range from low to high includes it.
By their numbers in this assay, from the lowest: compounds 1, 3 and 4 (each within the scatter of the next).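

In this assay the aromatic nitrogen now carries an open chain as well as aryl rings, and octyl gives a 1.1-fold higher number from compound 3 to compound 4 (0.04 log units; within the scatter) and a 1.2-fold higher number from compound 1 to compound 4 (0.07 log units; within the scatter) with neither step beyond the scatter. Replacing the six-membered aromatic ring of 2-ethylphenyl with a chain of the same heavy-atom count therefore leaves the number unchanged within the scatter. No measurement shown here offers an explanation for this.

As far as these compounds go, whether a shorter chain such as butyl, or an octyl chain ending in an amine or a carboxylic acid, would move the number beyond the scatter remains open. Compound 2 has no number to set beside these.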